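The compounds below may be only part of what the source reports. "The series", "measured", "known", "first", "only" and "open" are said of these compounds alone.

Compound 1 `O=C1C(Nc2ccccc2F)=CC(=O)c2c1nc1n2[C@H]2OC[C@@H](O)[C@H]2OC1` and compound 2 `O=C1C=C(Nc2cccc(F)c2)C(=O)c2c1nc1n2[C@H]2OC[C@@H](O)[C@H]2OC1` share one core and differ in where a fluorine sits on the phenyl ring attached to the amine nitrogen. In a functional assay on ECa-109 cells for inhibition, with ECa-109 cell line (Homo sapiens) as the target, read by sulforhodamine B assay (a lower number here means a stronger inhibitor, a higher number a weaker inhibitor), compound 1 gives 2660 nM, and compound 2 gives 7030 nM, so compound 1 has the lower of the two numbers, with a gap that is beyond the usual scatter.

Compound 3 `CCCc1ccc(NC2=CC(=O)c3c(nc4n3[C@H]3OC[C@@H](O)[C@H]3OC4)C2=O)cc1` has not yet been measured. It differs from compound 1 in one place: 4-propylphenyl in place of 2-fluorophenyl on an amine nitrogen. Among the compounds with values here, no measured pair shows what this exact change does, so the direction of the step can only be guessed. The step that is expected for this change is a 1.3-fold higher number from compound 1 to compound 3 (0.12 log units; within the scatter), and it is expected to be small, likely no bigger than the scatter. For compound 3 the estimated value in this assay is 3500 nM, with a range from 1000 nM to 12000 nM.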

Compound 3, half-maximal inhibitory concentration: > 4000 nM
Compound 3: a limit, no number; the forecaster's own chance of this, stated with the estimate: 10%; middle value at least 1.1-fold (0.05 log units) from the limit.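

In this assay, compound 3 gives > 4000 nM, which is a limit of the assay and not a number. As far as these compounds go, the change to 4-propylphenyl in place of 2-fluorophenyl on an amine nitrogen can therefore be read only as a floor, an at least 1.5-fold higher number from compound 1 to compound 3 (0.17 log units; that floor lies within the scatter), and the true size of the step stays unknown. Within the data shown here, compound 1 and compound 2 differ only in where a fluorine sits, whereas compound 3 is the first here to carry a carbon chain on this phenyl ring, and this swap gives no sign of a stronger inhibitor than compound 1.

Among these compounds, the single step swaps out the fluorine and brings in the propyl chain together, so their separate contributions remain open. A plain phenyl ring, or one carrying a methyl or methoxy group, would help pull the two apart.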